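Nitro removed from the fused ring: compound 3 to compound 4

The compounds below may be only part of what the source reports. "The series", "measured", "known", "first", "only" and "open" are said of these compounds alone.

Measured in a functional assay on MCF7 cells (Homo sapiens) for inhibition, read by MTT assay, with a stated time of 48 h, tested at 7.5 ug/mL; on this read-out lower numbers stand for less inhibition of growth and higher numbers for more inhibition of growth at the one concentration tested:
compound 1 `COc1cccc2c1OCN(c1ccc3oc(-c4ccccc4)cc(=O)c3c1)C2` gives 32.5%
compound 2 `Cc1cccc2c1OCN(c1ccc3oc(-c4ccccc4)cc(=O)c3c1)C2` gives 30.4%
compound 3 `O=c1cc(-c2ccccc2)oc2ccc(N3COc4c(cccc4[N+](=O)[O-])C3)cc12` gives 8.2%

Compound 3 stands lowest of the three numbers in this assay; its two neighbours are a number 24.3 percentage points lower from compound 1 to compound 3 (beyond the scatter) and a number 22.2 percentage points lower from compound 2 to compound 3 (beyond the scatter), both beyond the scatter, while a number 2.1 percentage points lower from compound 1 to compound 2 (within the scatter) stays within it. Compound 4 `O=c1cc(-c2ccccc2)oc2ccc(N3COc4ccccc4C3)cc12` is the unsubstituted parent of this group: hydrogen in place of nitro on an aromatic carbon. Among the compounds with values here, no measured step removes the nitro group directly, so the two steps that introduce it are the only ones that bear on this change, and they are read in reverse: nitro entering cost a modest amount each time, so hydrogen entering in its place is expected to give back a comparable amount in this assay. Whether the unsubstituted ring lands level with compounds 1 and 2 or short of them cannot be read from methyl or methoxy alone, so the range is kept wide. Compound 4 is estimated at 26% (range 8% to 44%), an expected step of a number 17.8 percentage points higher from compound 3 to compound 4 (beyond the scatter).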

Compound 4, percent growth inhibition at one concentration: 8.7%
Compound 4: the middle estimate sits 17.3 percentage points above what was measured; measured number inside the range.
By their numbers in this assay, from the lowest: compounds 3 and 4 (each within the scatter of the next); then compounds 2 and 1 (each within the scatter of the next).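

In this assay, the step to hydrogen, a number 0.5 percentage points higher from compound 3 to compound 4 (within the scatter), shows that nitro and hydrogen cannot be told apart at this position, so the low number of compound 3 is not a loss caused by nitro relative to the unsubstituted parent. The parent instead falls well short of the other two compounds, with a number 21.7 percentage points lower from compound 2 to compound 4 (beyond the scatter) and a number 23.8 percentage points lower from compound 1 to compound 4 (beyond the scatter), so among these four compounds it is methyl and methoxy that stand apart, not nitro. No supporting data bear on why this position responds in this way.

Going by these compounds, it remains open whether an amine, a carboxylic acid or a longer chain such as ethoxy at this position would stand with methyl and methoxy or with hydrogen and nitro. On these data alone, the same split at other positions on the shared core also remains open.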